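Cathepsin S inhibitors: varying the amide at the carbonyl

The source may hold more compounds than are shown below. What is called first, only, known or untested is meant among the compounds shown, and "the series" means these compounds.

Compound 1 `N#CC1(NC(=O)[C@@H]2C[C@@H](S(=O)(=O)c3ccccc3)C[C@H]2C(=O)N2CCCC2)CC1` and compound 2 `N#CC1(NC(=O)[C@@H]2C[C@@H](S(=O)(=O)c3ccccc3)C[C@H]2C(=O)N2CC(O)C2)CC1` share a core and differ only at one carbonyl carbon. Among the compounds with values here, in an assay on isolated protein for inhibition of cathepsin S (Homo sapiens), read by fluorescence, with a stated time of 20 min (on this read-out lower numbers stand for stronger inhibition and higher numbers for weaker inhibition), compound 1 gives 2 nM and compound 2 gives 7 nM; the step of a 3.5-fold higher number from compound 1 to compound 2 (0.54 log units; beyond the scatter) places compound 2 as the weaker of the two, and it stands at the higher end of the two numbers known so far. Compound 3 `CN(C)C(=O)[C@@H]1C[C@H](S(=O)(=O)c2ccccc2)C[C@H]1C(=O)NC1(C#N)CC1` carries the change (dimethylamino in place of 3-hydroxyazetidin-1-yl on a carbonyl carbon). Within the data shown here, only the single step from compound 1 to compound 2 bears on this change, and it was modest, so a step of similar or smaller size back towards the number of compound 1 is expected, though no measured pair shows exactly this acyclic group. For compound 3 the expected step is a 1.4-fold lower number from compound 2 to compound 3 (0.15 log units; within the scatter), and its estimated result in this assay is 5 nM with a range of 2 nM to 15 nM.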

Compound 3, half-maximal inhibitory concentration: 6 nM
For compound 3 the middle estimate is 1.2-fold (0.08 log units) below the measured one; low and high end bracket the measured number.
By their numbers in this assay, from the lowest: compound 1; then compounds 3 and 2 (each within the scatter of the next).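

In this assay the step from the 3-hydroxyazetidin-1-yl group to the acyclic dimethylamino group, a 1.2-fold lower number from compound 2 to compound 3 (0.07 log units; within the scatter), does not separate the two groups. Set against the pyrrolidin-1-yl group, the same dimethylamino group gives a 3.0-fold higher number from compound 1 to compound 3 (0.48 log units; beyond the scatter), so at this carbonyl carbon two quite different replacements, one with a ring and a hydroxyl and one with neither, both end up modestly apart from compound 1 and level with each other. Nothing available here accounts for these steps.

Going by these compounds, whether a diethylamino group or a piperidin-1-yl ring would return to the number of compound 1 remains open. So does the question of what the unsubstituted azetidin-1-yl group would give, which would show whether the hydroxyl on the four-membered ring counts for anything here.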